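The compounds below may be only part of what the source reports. "The series", "measured", "known", "first", "only" and "open" are said of these compounds alone.

Measured so far:
compound 1, `CN(C(=O)NC(=O)c1ccc([N+](=O)[O-])cc1)c1nc(C(F)(F)F)c(C(=O)N/N=C/c2cccc(C(F)(F)F)c2)s1`, 1.67 ug/mL
compound 2, `CN(C(=O)NC(=O)c1ccc(F)c(F)c1)c1nc(C(F)(F)F)c(C(=O)N/N=C/c2cccc(C(F)(F)F)c2)s1`, 4.46 ug/mL
compound 3, `CN(C(=O)NC(=O)c1c(F)cccc1F)c1nc(C(F)(F)F)c(C(=O)N/N=C/c2ccc(C(F)(F)F)cc2)s1`, 34.9 ug/mL

All three share one core and were tested in a functional assay on BCG823 cells (Homo sapiens) for inhibition, read by MTT assay, with a stated time of 72 h; on this read-out lower numbers stand for stronger inhibition and higher numbers for weaker inhibition. Compound 3 gives the highest number of the three: compound 2 stands nearer to it, compound 1 further away, and both gaps lie beyond the scatter. Among the compounds with values here, the only single-change step among the measured compounds is a 2.7-fold higher number from compound 1 to compound 2 (0.43 log units; beyond the scatter), a modest rise, and it concerns the group on the carbonyl carbon, not the part changed here.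

Compound 4, `CN(C(=O)NC(=O)c1c(F)cccc1F)c1nc(C(F)(F)F)c(C(=O)N/N=C/c2cccc(C(F)(F)F)c2)s1`, differs from compound 3 in one place: 3-(trifluoromethyl)phenyl in place of 4-(trifluoromethyl)phenyl on a carbon with a double bond to nitrogen. Within the data shown here, no measured step isolates this change. Compound 2 and compound 1 both carry the 3-(trifluoromethyl)phenyl group and give lower numbers than compound 3, but they also differ from compound 3 on the carbonyl carbon, so the two effects cannot be separated. The expectation is therefore a lower number for compound 4, held with wide uncertainty; the estimated step is a 2.9-fold lower number from compound 3 to compound 4 (0.46 log units; beyond the scatter). Compound 4 is estimated at 12 ug/mL, with a range from 3 ug/mL to 45 ug/mL.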

Compound 4, half-maximal inhibitory concentration: 25.9 ug/mL
Compound 4: middle estimate off by 2.2-fold (0.33 log units), on the low side; low and high end bracket the measured number.
By their numbers in this assay, from the lowest: compound 1; then compound 2; then compounds 4 and 3 (each within the scatter of the next).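

In this assay, 3-(trifluoromethyl)phenyl in place of 4-(trifluoromethyl)phenyl on a carbon with a double bond to nitrogen gives a 1.3-fold lower number from compound 3 to compound 4 (0.13 log units; within the scatter), so with 2,6-difluorophenyl on the carbonyl carbon, this swap makes no clear difference. The group on the carbonyl carbon does make a difference: with 3-(trifluoromethyl)phenyl held constant, the swaps give a 5.8-fold higher number from compound 2 to compound 4 (0.76 log units; beyond the scatter) and a 16-fold higher number from compound 1 to compound 4 (1.19 log units; beyond the scatter), so the lower numbers of compounds 1 and 2 go with their carbonyl-carbon groups. Nothing available here explains either result.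

From the compounds shown here alone, it remains open whether the swap between the two trifluoromethylphenyl groups would also make no clear difference with 4-nitrophenyl or 3,4-difluorophenyl on the carbonyl carbon. Also open, going by these compounds, is how a phenyl carrying an amine or a carboxylic acid would behave on the carbon with a double bond to nitrogen.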